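Dimethylamino-to-nitro swap on the aryl thiosemicarbazone series

The source may report more compounds than this note shows. Statements on the series, on what has been measured and on what is new or still open speak of the compounds shown alone.

Measured so far:
- compound 1, `CC1=CC[C@@H]([C@@](C)(O)CCCC(C)(C)NC(=S)N/N=C\c2ccccc2)CC1`: 12700 nM
- compound 2, `CC1=CC[C@@H]([C@@](C)(O)CCCC(C)(C)NC(=S)N/N=C\c2ccc(O)cc2)CC1`: 8870 nM
- compound 3, `CC1=CC[C@@H]([C@@](C)(O)CCCC(C)(C)NC(=S)N/N=C\c2ccc(N(C)C)cc2)CC1`: > 100000 nM

All three share one core and differ only on the benzylidene ring. In a functional assay on UACC-62 cells (Homo sapiens) for cytotoxicity, read by sulforhodamine B assay (on this read-out higher numbers stand for weaker inhibition of growth and lower numbers for stronger inhibition of growth), compound 1 gives 12700 nM and compound 2 gives 8870 nM; the hydroxy step is a 1.4-fold lower number from compound 1 to compound 2 (0.16 log units; within the scatter). Compound 3 gives only a limit in this assay, > 100000 nM. Compound 3 therefore stands at the weak end of the numbers shown, and the steps into it are an at least 7.8-fold higher number from compound 1 to compound 3 (0.89 log units; beyond the scatter) and an at least 11-fold higher number from compound 2 to compound 3 (1.05 log units; beyond the scatter); that 3 sits at the limit of > 100000 nM in this assay, at which 1 of the 3 values shown sits, means both are lower bounds on the loss.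

The next compound is compound 4, `CC1=CC[C@@H]([C@@](C)(O)CCCC(C)(C)NC(=S)N/N=C\c2ccccc2[N+](=O)[O-])CC1`. The change from compound 3 is 2-nitrophenyl in place of 4-(dimethylamino)phenyl on a carbon with a double bond to nitrogen. Two of the measured steps bear on this: removing dimethylamino reverses the direction of an at least 7.8-fold higher number from compound 1 to compound 3 (0.89 log units; beyond the scatter) and an at least 11-fold higher number from compound 2 to compound 3 (1.05 log units; beyond the scatter), so a return at least toward the level of compound 1 is expected. For the measured compounds named here, no measured step informs the 2-nitrophenyl itself, so its contribution is taken as neutral with wide uncertainty. The expected step is an at least 6.6-fold lower number from compound 3 to compound 4 (0.82 log units; beyond the scatter), downward and beyond the scatter. For compound 4 the estimated value is 15000 nM, with a range of 5000 nM to 60000 nM.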

Compound 4, concentration for 50% growth inhibition: 6050 nM
Beside the measured number, compound 4's estimate is 2.5-fold (0.39 log units) above it; measured number inside the range.
By their numbers in this assay, from the lowest: compounds 4, 2 and 1 (each within the scatter of the next, the first and the last beyond it). At a limit, above all of these: compound 3.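

In this assay, nitro is the first substituent on the aromatic ring whose step from the unsubstituted ring lies beyond the scatter, a modest gain shown by a 2.1-fold lower number from compound 1 to compound 4 (0.32 log units; beyond the scatter), whereas the step to 2-nitrophenyl from 4-hydroxyphenyl stays within it, as a 1.5-fold lower number from compound 2 to compound 4 (0.17 log units; within the scatter) shows, so those two groups cannot be ordered on this read-out. The large step of an at least 16-fold lower number from compound 3 to compound 4 (1.21 log units; beyond the scatter) shows that a substituted phenyl on the carbon with a double bond to nitrogen need not carry the loss seen with 4-(dimethylamino)phenyl, so that loss is not common to every substituted ring in the series. That step is only a lower bound, since compound 3 gives a limit and not a number: the limit of > 100000 nM in this assay, at which 1 of the 4 values shown sits.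

The compounds shown cannot separate the nitro group itself from the place it occupies on the ring, since the nitro and hydroxy groups and the dimethylamino group do not all sit at one ring position. As far as these compounds go, it also stays open whether a nitrile, a carboxylic acid, a primary amine or trifluoromethyl on the same ring would follow nitro or dimethylamino.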